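Aminoamino in place of methylsulfanyl on compound 1

The source may report more compounds than this note shows. Statements on the series, on what has been measured and on what is new or still open speak of the compounds shown alone.

compound 1 `CSc1nc(-c2ccco2)c(C#N)c(=O)n1C`: 90 ug/mL
compound 2 `CCOC(=O)c1cnn(-c2nc(-c3ccccc3O)c(C#N)c(=O)n2C)c1N`: 57 ug/mL
compound 3 `COc1cccc(-c2nc(NN)n(C)c(=O)c2C#N)c1OC`: 37 ug/mL

All three values come from a functional assay on microsomes for inhibition, with a stated time of 1 h; a lower number here means a stronger inhibitor, a higher number a weaker inhibitor. Compound 1 lies within the scatter of compound 2 and beyond the scatter of compound 3, whose number is the lower one.

Compound 4 `Cn1c(NN)nc(-c2ccco2)c(C#N)c1=O` has not yet been measured. It keeps the furan-2-yl group of compound 1 and differs in one place: aminoamino in place of methylsulfanyl on an aromatic carbon. This is aminoamino in place of methylsulfanyl on an aromatic carbon, between two ring nitrogen atoms.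

Among the compounds with values here, no measured pair isolates this change. Compound 3 carries the same aminoamino group and gives 37 ug/mL, but it also differs from compound 1 elsewhere, so the comparison is only a weak guide. On that limited evidence, a modest move towards a lower number is expected in this assay, and it may not exceed the scatter. The estimated step is a 1.8-fold lower number from compound 1 to compound 4 (0.26 log units; within the scatter), with the direction far from certain. Compound 4 is estimated at 50 ug/mL, with an expected range from 20 ug/mL to 110 ug/mL.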

Compound 4, half-maximal inhibitory concentration: 78 ug/mL
Compound 4: middle estimate off by 1.6-fold (0.19 log units), on the low side; low and high end bracket the measured number.
By their numbers in this assay, from the lowest: compounds 3, 2, 4 and 1 (each within the scatter of the next, the first and the last beyond it).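

In this assay, within the data shown here, this is the first pair that isolates the group on the aromatic carbon between two ring nitrogen atoms, with furan-2-yl held constant: a 1.2-fold lower number from compound 1 to compound 4 (0.06 log units; within the scatter). Within this pair, aminoamino and methylsulfanyl therefore cannot be told apart in this assay, even though the two groups differ in their counted hydrogen-bond donors and acceptors, and the number of compound 3 cannot be credited to the aminoamino group on the strength of this pair. No independent measurement bears on this result, so the flat step stands without an explanation.

From the compounds shown here alone, it remains open whether the same exchange gives a step of similar size when the aryl group of compound 3 replaces furan-2-yl on the shared core. Going by these compounds, it is also open whether any group at this position moves the number beyond the scatter, for example a plain amine, a morpholine or a longer chain such as butylamino.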